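Working notes on a sulfanyl-for-amino swap at the shared core

A few compounds are considered here, and "the series" means these few. Any claim that something is new, unique, unknown or untested is made for them only; others in the source may bear on it.

Measured so far in an assay for inhibition of MAP kinase-interacting serine/threonine-protein kinase 2 (Homo sapiens), read by TR-FRET; on this read-out higher numbers stand for weaker inhibition and lower numbers for stronger inhibition:
compound 1 `COCCSc1nc(C)c(-c2ccnc(Nc3ccc(OC)cc3OC)n2)s1` gives 1700 nM
compound 2 `COc1ccc(Nc2nccc(-c3sc(SCc4cccnc4)nc3C)n2)c(OC)c1` gives 400 nM
compound 3 `COc1ccc(Nc2nccc(-c3sc(N(C)C)nc3C)n2)c(OC)c1` gives 200 nM

Compound 3 has the lowest number of the three; the gap to compound 2 is within the scatter, so no order between them is claimed, while the gap to compound 1 is clear. Compound 4 `COc1ccc(Nc2nccc(-c3sc(SCCCN(C)C)nc3C)n2)c(OC)c1` is not yet measured; it differs from compound 3 by (3-(dimethylamino)propyl)sulfanyl in place of dimethylamino on an aromatic carbon.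

For the measured compounds named here, two measured steps bear on this change, read in reverse. Replacing a sulfanyl chain by dimethylamino gave an 8.5-fold lower number from compound 1 to compound 3 (0.93 log units; beyond the scatter) and a 2.0-fold lower number from compound 2 to compound 3 (0.30 log units; within the scatter). Going back from dimethylamino to a sulfanyl chain should therefore raise the number, modestly. Going by the values given here, the (dimethylamino)propyl chain has no measured counterpart, which widens the range.

For compound 4 in this assay the expected step is a 2.5-fold higher number from compound 3 to compound 4 (0.40 log units; beyond the scatter), giving an estimate of 500 nM with a range of 200 nM to 1500 nM.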

Compound 4, inhibition constant: 1150 nM
Compound 4: middle estimate off by 2.3-fold (0.36 log units), on the low side, and the stated range covers the measured number.
By their numbers in this assay, from the lowest: compounds 3 and 2 (each within the scatter of the next); then compounds 4 and 1 (each within the scatter of the next).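

In this assay, the (3-(dimethylamino)propyl)sulfanyl chain gives a 5.8-fold higher number from compound 3 to compound 4 (0.76 log units; beyond the scatter), so this sulfanyl chain, like that of compound 1, stands clearly apart from dimethylamino on this aromatic carbon, while the chain of compound 2 goes against this by staying within the scatter. Swapping groups on the chain gives a 1.5-fold lower number from compound 1 to compound 4 (0.17 log units; within the scatter) for (dimethylamino)methyl in place of methoxy, but a 2.9-fold higher number from compound 2 to compound 4 (0.46 log units; beyond the scatter) for 2-(dimethylamino)ethyl in place of pyridin-3-yl. No evidence on hand accounts for these steps.

Open, going by these compounds, is whether methylsulfanyl or morpholine on this carbon would stay within the scatter of compound 3, and what a carboxylic acid on the chain would do.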